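The source may hold more compounds than are shown below. What is called first, only, known or untested is meant among the compounds shown, and "the series" means these compounds.

In an assay for inhibition of Fatty-acid amide hydrolase 1 (Rattus norvegicus) (on this read-out higher numbers stand for weaker inhibition and lower numbers for stronger inhibition), compound 2 `O=C(O)c1cc(-c2cnc(C(=O)CCc3ccc(-c4ccccc4)cc3)o2)ccn1` gives 50 nM, the lowest of the three numbers recorded for the series. Compound 1 `COC(=O)c1cccc(-c2cnc(C(O)CCc3ccc(-c4ccccc4)cc3)o2)n1` gives 9000 nM in this assay, and compound 3 `NC(=O)c1ccc(-c2cnc(CCCc3ccc(-c4ccccc4)cc3)o2)nc1` gives 30000 nM in this assay. Both of these lie above compound 2 by margins well beyond the scatter. For the measured compounds named here, no two of the three measured compounds differ in a single place, so no measured step is available to calibrate a change on the shared core.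

Compound 4 `O=C(CCc1ccc(-c2ccccc2)cc1)c1ncc(C(=O)C(F)(F)F)o1` is the next compound to be measured in this assay. It differs from compound 2 in one place:

(trifluoromethyl)carbonyl in place of 2-carboxypyridin-4-yl on an aromatic carbon

Going by the values given here, every measured compound carries an aromatic six-membered ring at this aromatic carbon; compound 4 is the first without one, and the numbers give no direct guidance on what that means. The change is therefore expected to move the number upward, toward weaker inhibition, by more than the scatter, but the size rests on judgment alone. The step expected from compound 2 to compound 4 is a 10-fold higher number from compound 2 to compound 4 (1.00 log units; beyond the scatter). For compound 4 the estimated value in this assay is 500 nM, with a range from 60 nM to 4000 nM.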

Compound 4, inhibition constant: 8 nM
Compound 4: middle estimate off by 63-fold (1.80 log units), on the high side; measured number outside the range, below it.
By their numbers in this assay, from the lowest: compound 4; then compound 2; then compound 1; then compound 3.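

Replacing 2-carboxypyridin-4-yl with (trifluoromethyl)carbonyl on this aromatic carbon gives a 6.3-fold lower number from compound 2 to compound 4 (0.80 log units; beyond the scatter) in this assay, so a low number at this position does not depend on a six-membered aromatic ring. The position also accepts a group with no ring and no hydrogen-bond donor, and the number falls rather than rises on this change. No measurement on hand accounts for the step, and its origin stays unassigned.

The change removes the ring and the carboxylic acid and brings in the trifluoromethyl and its carbonyl in one move, so the compounds shown do not separate the contribution of each part; a plain pyridin-4-yl without the carboxylic acid, or an acetyl group in place of the (trifluoromethyl)carbonyl, would pull these apart. As far as these compounds go, the role of the carbonyl in the chain also stays open, as compound 1 and compound 3 differ from compound 2 in more than one place, and a matched pair carrying a hydroxyl or a methylene there on an otherwise unchanged compound 4 would address it.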